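A few compounds are considered here, and "the series" means these few. Any claim that something is new, unique, unknown or untested is made for them only; others in the source may bear on it.

Measured compounds:
compound 1 `COc1cccc2c1OCC(C)(C)C2N` with 4.3%
compound 2 `COc1cccc2c1C(O)C(C)(C)CO2` with 5.3%
compound 3 `CC1(C)COc2ccccc2C1N` with 3.7%

In an assay on BTI cells for inhibition of Amine oxidase [flavin-containing] B (Homo sapiens), read by fluorescence, with a stated time of 20 min, tested at 1 uM (a higher number here means more inhibition at the concentration tested (going by the name of the read-out), a lower number less inhibition), compound 3 stands lowest of the three numbers, yet both compound 1 and compound 2 lie within the scatter of it. Among the compounds with values here, the one measured step, a number 0.6 percentage points lower from compound 1 to compound 3 (within the scatter), is hydrogen in place of methoxy on an aromatic carbon and falls within the scatter. Compound 4 `C#CCNC1c2ccccc2OCC1(C)C` differs from compound 3 by propargyl in place of hydrogen on an amine nitrogen. No measured step touches the amine nitrogen, so nothing among these compounds tells how large this change should be in this assay, and the range must be wide. Compound 4 is therefore estimated at 45%, between 5% and 90%, an expected step of a number 41.3 percentage points higher from compound 3 to compound 4 (beyond the scatter).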

Compound 4, a percentage reported as inhibition, at one concentration (the size of the read-out at that concentration, not a potency): 11.6%
Estimate against measurement, compound 4: 33.4 percentage points above; measured number inside the range.
By their numbers in this assay, from the lowest: compounds 3, 1, 2 and 4 (each within the scatter of the next).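

In this assay, the amine nitrogen now has its first measured step: propargyl in place of hydrogen gives a number 7.9 percentage points higher from compound 3 to compound 4 (within the scatter). At this one concentration, then, amino and propargylamino on this nitrogen cannot be told apart, and the change is not shown to alter the read-out. Nothing measured here bears on the reason for this result. Going by these compounds, it remains open whether a methyl group or a longer chain on this nitrogen would read differently. On these data alone, it is also open whether propargyl would read the same on the core of compound 1, which carries methoxy.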